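Oxolanyloxy for methoxy on two acrylamide-bearing cores

A few compounds are considered here, and "the series" means these few. Any claim that something is new, unique, unknown or untested is made for them only; others in the source may bear on it.

Measured compounds in a functional assay on A549 cells (Homo sapiens) for antiproliferative activity, read by MTT assay, with a stated time of 72 h; a higher number here means a weaker inhibitor, a lower number a stronger inhibitor:
- compound 1, `C=C(C)C(=O)Nc1cc2c(N3CCc4ccccc43)ncnc2cc1OC`, gives 7320 nM
- compound 2, `C=C(C)C(=O)Nc1cc2c(N3CCc4ccccc43)ncnc2cc1O[C@@H]1CCOC1`, gives 16600 nM
- compound 3, `COc1cc2ncnc(N3CCCc4ccccc43)c2cc1NC(=O)/C=C/CN(C)C`, gives 1650 nM

Compound 3 has the lowest number of the three; compound 1 stands nearest to it and compound 2 furthest, both gaps beyond the scatter. The difference between the core of compound 1 and the core of compound 3 is not broken down here.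

One change is seen twice in the set. From compound 1 to compound 2 it reads (oxolan-3-yl in place of methyl on an oxygen on an aromatic ring), and the step it made was a 2.3-fold higher number from compound 1 to compound 2 (0.36 log units; beyond the scatter). Among the compounds with values here, compound 4, `CN(C)C/C=C/C(=O)Nc1cc2c(N3CCCc4ccccc43)ncnc2cc1O[C@@H]1CCOC1`, is not yet measured; it differs from compound 3 by oxolan-3-yl in place of methyl on an oxygen on an aromatic ring, the same change at the same kind of place as the one from compound 1 to compound 2.

For compound 4 the expectation is a step of a 2.3-fold higher number from compound 3 to compound 4 (0.36 log units; beyond the scatter) in this assay, resting on the measured step of a 2.3-fold higher number from compound 1 to compound 2 (0.36 log units; beyond the scatter) applied to the value of compound 3, which is 1650 nM. Since the change is seen only once in measured form, and on a different core, the range around this expectation is kept wide. The estimate for compound 4 in this assay is 3800 nM, expected to fall between 1500 nM and 9500 nM.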

Compound 4, half-maximal inhibitory concentration: 2320 nM
Compound 4: the middle estimate sits 1.6-fold (0.21 log units) above what was measured; low and high end bracket the measured number.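

In this assay, replacing methoxy with (oxolan-3-yl)oxy on the second core gives a 1.4-fold higher number from compound 3 to compound 4 (0.15 log units; within the scatter). Set beside the step on the first core, the change carries over without a measurable difference in size: the same change on two cores in this assay, a 2.3-fold higher number (0.36 log units; beyond the scatter) from compound 1 to compound 2 and a 1.4-fold higher number (0.15 log units; within the scatter) from compound 3 to compound 4, 1.6-fold (0.21 log units) apart, within the scatter of two such steps. This agreement rests on a single pair on each core and does not establish a fixed size for the step, nor does it show that the change would behave alike on any other core; the two cores also differ in more than one place, so these pairs cannot show which of those differences, if any, bears on the size of the step.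

On the oxygen on the aromatic ring, the compounds shown carry only methyl and one defined stereoisomer of oxolan-3-yl, which leaves open how the opposite stereoisomer, a longer chain such as 2-methoxyethyl, or a ring bearing an amine such as piperidin-4-yl would read on either core. As far as these compounds go, all of these readings also come from one cell line in one assay, so whether the change behaves in the same way in any other measurement remains open.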